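A few compounds are considered here, and "the series" means these few. Any claim that something is new, unique, unknown or untested is made for them only; others in the source may bear on it.

Measured so far in an ADME assay on ECV-304 cells (Homo sapiens) for cytotoxicity, read by MTT assay, with a stated time of 72 h; on this read-out lower numbers stand for stronger inhibition and higher numbers for weaker inhibition:
- compound 1 `COc1ccc(C2=C(c3cc(OC)c(OC)c(OC)c3)C(=O)C(OC(C)=O)C2)cc1OC(C)C`: > 100 ug/mL, a limit
- compound 2 `COc1ccc(C2=C(c3cc(OC)c(OC)c(OC)c3)C(=O)CC2O[SiH2]C(C)(C)C)cc1`: > 100 ug/mL, a limit
- compound 3 `COc1ccc(OC)c(C2=C(c3cc(OC)c(OC)c(OC)c3)C(=O)CC2O[SiH2]C(C)(C)C)c1`: 6.5 ug/mL

Within the data shown here, compound 3 is the only compound with an actual number, 6.5 ug/mL. The rest of the series sits at the limit of > 100 ug/mL in this assay, at which 2 of the 3 values shown sit.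

The next compound, compound 4 `COC(=O)c1cc(C2=C(c3cc(OC)c(OC)c(OC)c3)C(=O)CC2O[SiH2]C(C)(C)C)ccc1OC`, changes one group of compound 3: 4-methoxy-3-(methoxycarbonyl)phenyl in place of 2,5-dimethoxyphenyl on a double-bonded ring carbon. In words, 4-methoxy-3-(methoxycarbonyl)phenyl stands in place of 2,5-dimethoxyphenyl on a double-bonded ring carbon.

Among the measured compounds shown here, one measured step bears on this place: an at least 15-fold lower number from compound 2 to compound 3 (1.18 log units; beyond the scatter), large and beyond the scatter. Compound 4 gives up the 2,5-dimethoxyphenyl group present in that step's more inhibitory partner and, like compound 2, carries a 4-methoxy group on the ring. Compound 2 reads > 100 ug/mL, a limit. A move toward weaker inhibition is therefore expected, though smaller than the measured step and resting on that single step. The expected change is a 3.8-fold higher number from compound 3 to compound 4 (0.59 log units; beyond the scatter). For compound 4 the estimate is 25 ug/mL, with an expected range of 5 ug/mL to 100 ug/mL.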

Compound 4, half-maximal inhibitory concentration: > 100 ug/mL
Compound 4: no number, only a limit (the forecaster's own chance of this, stated with the estimate: 35%); middle value at least 4.0-fold (0.60 log units) away from the limit.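

In this assay, putting 4-methoxy-3-(methoxycarbonyl)phenyl in place of 2,5-dimethoxyphenyl on the double-bonded ring carbon gives an at least 15-fold higher number from compound 3 to compound 4 (1.18 log units; beyond the scatter), so a second replacement at this position also loses the measurable value. Compound 4 gives > 100 ug/mL, which is a limit; compound 2 also reads as a limit, so the step between them, which adds methoxycarbonyl to the aromatic ring, cannot be read. Among compound 2, compound 3 and compound 4, only the 2,5-dimethoxyphenyl group gives a number: the limit of > 100 ug/mL in this assay, at which 3 of the 4 values shown sit.

From the compounds shown here alone, it remains open whether a phenyl ring bearing just one of the two methoxy groups of 2,5-dimethoxyphenyl would keep a measurable value. Also open, going by these compounds, is whether a carboxylic acid or an amide in place of the methoxycarbonyl of compound 4 would bring a number back.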